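The compounds below may be only part of what the source reports. "The series", "measured", "known", "first", "only" and "open" are said of these compounds alone.

Compound 1 `CCC(=O)Nc1cccc(S(=O)(=O)Oc2ccccc2C(C)C)c1` gives 14000 nM in a functional assay on MCF7 cells (Homo sapiens) for antiproliferative activity, read by sulforhodamine B assay, with a stated time of 48 h; a higher number here means a weaker inhibitor, a lower number a stronger inhibitor.
Compound 2 `CCCC(=O)Nc1cccc(S(=O)(=O)Oc2ccccc2C(C)C)c1` gives 9400 nM.
Compound 3 `CC(C)C(=O)Nc1ccc(S(=O)(=O)Oc2ccccc2C(C)C)cc1` gives 8600 nM.

Compound 1 and compound 2 differ by methyl in place of hydrogen on a saturated chain carbon, two bonds along the chain from a carbonyl carbon, and this change brought a 1.5-fold lower number from compound 1 to compound 2 (0.17 log units; within the scatter). Compound 4 `CC(C)c1ccccc1OS(=O)(=O)c1ccc(NC(=O)C(C)(C)C)cc1`, not yet measured, stands to compound 3 as methyl in place of hydrogen on a saturated chain carbon bound to a carbonyl carbon and two saturated chain carbons. It is the same kind of change, not the same: in compound 2 the methyl sits two bonds along the chain from a carbonyl carbon, while in compound 4 it sits on a carbon bound to a carbonyl carbon and two saturated chain carbons. The difference between the core of compound 1 and the core of compound 3 is not broken down here. Since the earlier methyl step stayed within the scatter, the step from compound 3 to compound 4 in this assay is expected to be small, about a 1.2-fold lower number from compound 3 to compound 4 (0.09 log units; within the scatter). Compound 4 is therefore estimated at 7000 nM, between 3500 nM and 14000 nM.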

Compound 4, half-maximal inhibitory concentration: 6500 nM
Compound 4: the middle estimate sits 1.1-fold (0.03 log units) above what was measured; low and high end bracket the measured number.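

In this assay, the added methyl brought a 1.3-fold lower number from compound 3 to compound 4 (0.12 log units; within the scatter). Set beside the earlier methyl step, the change reads alike on the two cores: the same change on two cores in this assay, a 1.5-fold lower number (0.17 log units; within the scatter) from compound 1 to compound 2 and a 1.3-fold lower number (0.12 log units; within the scatter) from compound 3 to compound 4, 1.1-fold (0.05 log units) apart, within the scatter of two such steps. This shows that adding one methyl to the saturated chain stayed within the scatter on both cores, but it does not show that the methyl improves activity, and two pairs, with the methyl in different places, set no rule for other cores.

No pair shown differs in the core alone, so what the core itself contributes stays open. Also open, as far as these compounds go, is what a longer chain, an amine or a carboxylic acid in place of the tert-butyl group would do.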